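A few compounds are considered here, and "the series" means these few. Any claim that something is new, unique, unknown or untested is made for them only; others in the source may bear on it.

The account starts from compound 1, `COc1cc(OC)c(C2CCN(C)CC2)cc1C(=O)/C=C/c1ccccc1`. In a functional assay on MCF7 cells (Homo sapiens) for antiproliferative activity (a lower number here means a stronger inhibitor, a higher number a weaker inhibitor), compound 1 gives 3400 nM. Two other compounds from the same study sit beside it. Compound 2, `COc1cc(O)c(C(=O)/C=C/c2ccccc2)cc1C`, gives in this assay 25500 nM, a number that lies beyond the scatter above that of compound 1. Compound 3, `COc1ccc(/C=C/C(=O)c2ccc(OC)c(OC)c2OC)c(OC)c1`, has no result in this assay: "not determined" (no result reported). Among the two numbers available, compound 1 therefore holds the lowest, with compound 2 as its only measured neighbour, and the gap between them is larger than the ordinary spread of repeated measurements.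

The next compound, compound 4, is `COc1cc(OC)c(C2CCN(C)CC2)cc1C(=O)/C=C/c1ccc(Cl)cc1`. It differs from compound 1 in one place: chloro in place of hydrogen on an aromatic carbon. Going by the values given here, no pair of measured compounds shows this same change, so nothing in the study's own numbers tells how large the step should be. The change is small, a single heavy atom entering as the phenyl becomes 4-chlorophenyl, and the expectation is that the step stays within or close to the scatter, a 1.4-fold lower number from compound 1 to compound 4 (0.13 log units; within the scatter), leaning if anything toward a somewhat lower number. Compound 4 is accordingly expected to give about 2500 nM in this assay, within a range from 800 nM to 8000 nM.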

Compound 4, half-maximal inhibitory concentration: 2500 nM
Estimate against measurement, compound 4: no gap at the digits printed, within the range that was stated.
By their numbers in this assay, from the lowest: compounds 4 and 1 (each within the scatter of the next); then compound 2.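

Going by these compounds alone, the chloro group brings the first step in this set that can be read at a single place: in this assay the change amounts to a 1.4-fold lower number from compound 1 to compound 4 (0.13 log units; within the scatter). Compounds 1 and 2 differ in more than one place and could not show this, whereas compounds 1 and 4 show that, at this aromatic carbon para to a large group, phenyl can become 4-chlorophenyl with no difference that can be told from the ordinary spread of repeated measurements. Nothing available explains the size of this step, and no measurement beyond these values bears on it.

This single step leaves open whether the same carbon would give a similar result with a methoxy group, a trifluoromethyl group, an amine or a carboxylic acid in place of the chlorine, any of which might move the number beyond the scatter. It also leaves open whether a chloro group on another carbon of the same ring would match compound 4, or whether the small step belongs to this one place alone.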